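The source may report more compounds than this note shows. Statements on the series, on what has been measured and on what is new or still open speak of the compounds shown alone.

Measured compounds:
- compound 1, `CCC(C)C(=O)Nc1c(C(O)(C(F)(F)F)C(F)(F)F)ccc2ccccc12`: 177000 nM in an assay on LtK cells with ATP-sensitive inward rectifier potassium channel 11 (Homo sapiens) as the target; on this read-out lower numbers stand for an effect already at smaller amounts and higher numbers for an effect only at larger amounts of compound
- compound 2, `CCC(CC)C(=O)Nc1c(C(O)(C(F)(F)F)C(F)(F)F)ccc2ccccc12`: 4340 nM in this assay
- compound 3, `CC(C)=CC(=O)Nc1c(C(O)(C(F)(F)F)C(F)(F)F)ccc2ccccc12`: 46 nM in this assay

Compound 3 stands lowest of the three numbers in this assay; its nearest neighbour is compound 2, as shown by a 94-fold lower number from compound 2 to compound 3 (1.97 log units; beyond the scatter), and compound 1 lies furthest away, as shown by a 3800-fold lower number from compound 1 to compound 3 (3.59 log units; beyond the scatter). Both of these steps exchange a saturated branched chain on the carbonyl carbon for the 2-methylprop-1-en-1-yl group, and both are large.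

Compound 4, `CCCC(C)C(=O)Nc1c(C(O)(C(F)(F)F)C(F)(F)F)ccc2ccccc12`, is not yet measured. The change from compound 3 reads (1-methylbutyl in place of 2-methylprop-1-en-1-yl on a carbonyl carbon). This reverses the direction of the two steps above: the chain entering is saturated, as in compound 1 and compound 2, and carries the same count of carbons as the chain of compound 2. Among the saturated chains, a 41-fold lower number from compound 1 to compound 2 (1.61 log units; beyond the scatter) shows that adding one carbon on the chain moved the number down by a large margin, so the number for compound 4 is expected to fall between those of compound 1 and compound 2 rather than near compound 3.

On this basis compound 4 is estimated at 12000 nM in this assay, with a range from 2000 nM to 70000 nM, which means an expected step of a 260-fold higher number from compound 3 to compound 4 (2.42 log units; beyond the scatter).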

Compound 4, half-maximal effective concentration: > 10000 nM
Compound 4 ended at the assay's limit; the forecaster's own chance of this, stated with the estimate: 5%; the middle value is on the limit's open side.
By their numbers in this assay, from the lowest: compound 3; then compound 2; then compound 1.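

In this assay compound 4 gives > 10000 nM, which is a limit of the assay and not a number: the limit of > 10000 nM in this assay, at which 1 of the 4 values shown sits.

Even read against that limit, the change on the carbonyl carbon gives an at least 210-fold higher number from compound 3 to compound 4 (2.33 log units; beyond the scatter), so 1-methylbutyl joins the saturated chains of compound 1 and compound 2 in standing well apart from the 2-methylprop-1-en-1-yl group, and none of the compounds shown goes against this. The series also yields an at least 2.3-fold higher number from compound 2 to compound 4 (0.36 log units; beyond the scatter), which shows that this position tells apart two saturated branched chains of the same carbon count, pentan-3-yl and 1-methylbutyl, so the count alone does not set the number.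

The step between the chains of compound 1 and compound 4 cannot be read, which leaves their order open. Also open, going by these compounds, is whether the double bond itself accounts for the low number of compound 3, a question that the saturated counterpart of its chain, 2-methylpropyl, would address directly, with a cyclopropyl group or a longer alkenyl chain testing how far the effect extends.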